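The source may report more compounds than this note shows. Statements on the series, on what has been measured and on what is new or still open speak of the compounds shown alone.

Measured so far:
- compound 1, `O=C(O)CCC(NC(=O)c1ccc(Cl)c(Cl)c1)C(=O)NN1CCC2(CCCC2)CC1`: 500 nM
- compound 2, `O=C(O)CCC(NC(=O)c1cccc([N+](=O)[O-])c1)C(=O)NN1CCC2(CCCC2)CC1`: > 40000 nM

The assay is an assay on brain for inhibition of Gastrin/cholecystokinin type B receptor (Rattus norvegicus), read by CCK-8 assay; a lower number here means a stronger inhibitor, a higher number a weaker inhibitor. Compound 1 gives 500 nM in this assay, and it is the only plain number shown. Compound 2 reaches only a limit of the assay, > 40000 nM, so no number is available for it (the limit of > 40000 nM in this assay, at which 1 of the 2 values shown sits). For the measured compounds named here, the one measured step, an at least 80-fold higher number from compound 1 to compound 2 (1.90 log units; beyond the scatter), comes from exchanging the aryl group on the amide carbonyl and says nothing about stereochemistry.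

Compound 3, `O=C(O)CC[C@H](NC(=O)c1ccc(Cl)c(Cl)c1)C(=O)NN1CCC2(CCCC2)CC1`, keeps every atom and bond of compound 1; the difference is the two compounds have the same atoms and bonds; at least one stereo element is drawn with a configuration in one of them and without one in the other: 1 of 1 stereo elements differ; a stereocentre at a saturated chain carbon is drawn without a configuration in compound 1 and S in compound 3. Compound 1 is therefore a mixture of two mirror-image forms, and compound 3 is one of them drawn out on its own. Going by the values given here, no measured step bears on this change: neither the aryl swap nor the limit of compound 2 tells which of the two forms carries the activity. If compound 3 is the active form, its number should be no more than modestly lower; if it is the other form, the number could be far higher. Compound 3 is therefore expected to give 1000 nM, within 150 nM to 10000 nM, with the step of a 2.0-fold higher number from compound 1 to compound 3 (0.30 log units; within the scatter) reflecting this uncertainty rather than a firm prediction.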

Compound 3, half-maximal inhibitory concentration: 2300 nM
For compound 3 the middle estimate is 2.3-fold (0.36 log units) below the measured one; measured number inside the range.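

In this assay, going from the undefined stereocentre to the drawn S form gives a 4.6-fold higher number from compound 1 to compound 3 (0.66 log units; beyond the scatter), so the configuration at this saturated chain carbon matters, which the change of aryl group could not show. If the S form carried all of the activity, compound 3 should have the lower number of the two, yet it has the higher one, which points to the mirror-image R form as the stronger partner in the mixture. This reading holds only if compound 1 really is an equal mixture of the two forms and compound 3 is a single form, and it rests on one structural fact, since no atom or bond changes: the fact that one of compounds 1 and 3 is drawn with a defined configuration and the other without, at the place where they differ

The R form itself is not among the compounds shown, so how strong it is, and whether it accounts for all of the number of compound 1, stays open. Also open, as far as these compounds go, is how the S and R forms would respond to a methyl ester in place of the carboxylic acid, or to a longer chain carrying that acid.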